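The source may report more compounds than this note shows. Statements on the series, on what has been measured and on what is new or still open speak of the compounds shown alone.

Measured so far in a functional assay on PC-3 cells (Homo sapiens) for antiproliferative activity, read by MTT assay, with a stated time of 24 h; on this read-out lower numbers stand for stronger inhibition and higher numbers for weaker inhibition:
- compound 1 `CCn1c(C(=O)NCCN)ccc1C(CC)(CC)c1ccc(OCS(=O)(=O)c2ccccc2)c(C)c1`: 6890 nM
- compound 2 `CCn1c(C(=O)N[C@@H](CO)CCCO)ccc1C(CC)(CC)c1ccc(OCS(=O)(=O)c2ccccc2)c(C)c1`: 13400 nM

Going by the values given here, compound 2 lies within the usual scatter of compound 1, the only other measured compound, so the two cannot be ranked. Compound 3 `CCn1c(C(=O)NC2(C(=O)O)CC2)ccc1C(CC)(CC)c1ccc(OCS(=O)(=O)c2ccccc2)c(C)c1` keeps the shared core and changes only the group on the amide-type nitrogen: a group of 6 heavy atoms (4 carbon, 2 oxygen; one three-membered non-aromatic ring of carbon only) in place of a group of 7 heavy atoms (5 carbon, 2 oxygen; no ring), on an amide-type nitrogen. The entering group is 1-carboxycyclopropyl. Among the compounds with values here, the one measured step that bears on this change is a 1.9-fold higher number from compound 1 to compound 2 (0.29 log units; within the scatter). It swapped a group at the same place and stayed within the scatter. This single step is thin evidence, and neither measured compound has a ring in that group. No step beyond the scatter is therefore expected in this assay, though the uncertainty is wide. The estimated value for compound 3 is 12000 nM, with an expected range of 4000 nM to 36000 nM. The expected step is a 1.1-fold lower number from compound 2 to compound 3 (0.05 log units; within the scatter).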

Compound 3, half-maximal inhibitory concentration: 26300 nM
Beside the measured number, compound 3's estimate is 2.2-fold (0.34 log units) below it, within the range that was stated.
By their numbers in this assay, from the lowest: compounds 1, 2 and 3 (each within the scatter of the next, the first and the last beyond it).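

In this assay, the group on the amide-type nitrogen can shift the number beyond the scatter: 1-carboxycyclopropyl in place of 2-aminoethyl gives a 3.8-fold higher number from compound 1 to compound 3 (0.58 log units; beyond the scatter), a modest step and the first of its kind in this series. Against the open-chain group of compound 2, the same ring-bearing group gives a 2.0-fold higher number from compound 2 to compound 3 (0.29 log units; within the scatter), so compound 3 separates from compound 1 but cannot be ranked against compound 2. No measurement at hand explains the step from the 2-aminoethyl group.

From the compounds shown here alone, the ring and the carboxylic acid arrive together in 1-carboxycyclopropyl, so it stays open which of them goes with that step. A plain cyclopropyl group and an open-chain carboxymethyl group on the same nitrogen would pull the two apart.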